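The compounds below may be only part of what the source reports. "The series", "measured", "known", "first", "only" and "open" are said of these compounds alone.

Of the compounds shown here, three have so far been tested in a functional assay on HCT-116 cells (Homo sapiens) for antiproliferative activity, read by CCK-8 assay, with a stated time of 72 h, tested at 8 uM; on this read-out lower numbers stand for a weaker effect and higher numbers for a stronger effect at the one concentration tested. Compound 1 `CC(C)n1cnc2c(Nc3ccccc3)nc(NCOCc3ccc(C(=O)Nc4ccccc4N)cc3)nc21` gives 18.8% in this assay. Compound 2 `CC(C)n1cnc2c(NCc3ccc(C(=O)Nc4ccccc4N)cc3)nc(Cl)nc21` gives 76%, and compound 3 `Nc1ccccc1NC(=O)c1ccc(CNc2nc(Cl)nc3c2ncn3C2CCCC2)cc1` gives 80.6%. Compound 3 is compound 2 with one group exchanged, cyclopentyl in place of isopropyl on an aromatic nitrogen, and that exchange produced a number 4.6 percentage points higher from compound 2 to compound 3 (within the scatter); in plain terms, the two numbers cannot be told apart with confidence. Compound 1 and compound 2 are built on different frameworks, and the difference between the two cores is not broken down here. What the numbers show is that compound 1 lies far below compound 2 and compound 3, both gaps being beyond the usual scatter.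

Compound 4 `Nc1ccccc1NC(=O)c1ccc(COCNc2nc(Nc3ccccc3)c3ncn(C4CCCC4)c3n2)cc1` has not yet been measured. It is derived from compound 1 by exactly the same exchange, cyclopentyl in place of isopropyl on an aromatic nitrogen, at a place described in identical words, so this change occurs twice among the four compounds. For the measured compounds named here, the only measured instance of it left the read-out essentially unchanged, and the expectation for compound 4 rests on that single instance, a number 4.6 percentage points higher from compound 2 to compound 3 (within the scatter). Compound 4 is therefore expected to sit close to compound 1, with the expected step being a number 3.2 percentage points higher from compound 1 to compound 4 (within the scatter). The estimated read-out for compound 4 is 22%, expected to fall between 8% and 40%.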

Compound 4, a percentage reported as inhibition, at one concentration (the size of the read-out at that concentration, not a potency): 76.9%
For compound 4 the middle estimate is 54.9 percentage points below the measured one; measured number outside the range, above it.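

In this assay, exchanging isopropyl for cyclopentyl on an aromatic nitrogen of the core of compound 1 produced a number 58.1 percentage points higher from compound 1 to compound 4 (beyond the scatter), so this small change turned a low read-out into a high one. Set beside the earlier pair, the same exchange clearly did not carry over with the same size from one core to the other: the same change on two cores in this assay, a number 4.6 percentage points higher (within the scatter) from compound 2 to compound 3 and a number 58.1 percentage points higher (beyond the scatter) from compound 1 to compound 4, 53.5 percentage points apart, beyond the scatter of two such steps. For the compounds shown here, this shows that, in this series, a step measured on one core can be a poor guide to the step on another, since the outcome of the exchange depends on the core that carries it; it does not show why the two cores differ, and it rests on only two pairs, read at one concentration, so it gives no rule for any further core.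

Only isopropyl and cyclopentyl appear on this nitrogen, so the compounds shown leave open how a plain ethyl chain or a cyclohexyl ring would behave on either core. They also leave open whether the large step on the core of compound 1, a stronger effect at the one concentration tested, would hold at other concentrations, which a read-out at a single concentration cannot tell.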